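A few compounds are considered here, and "the series" means these few. Any claim that something is new, unique, unknown or untested is made for them only; others in the source may bear on it.

In a functional assay on MDA-MB-435 cells (Homo sapiens) (on this read-out higher numbers stand for weaker inhibition of growth and lower numbers for stronger inhibition of growth), compound 3 `COc1ccccc1-c1cc(O)c2cccnc2n1` gives 39800 nM while compound 2 `COc1ccccc1-c1cc(O)c2ccc(C)nc2n1` gives 21900 nM and compound 1 `COc1ccc(-c2cc(O)c3cccnc3n2)cc1` gives 20000 nM on the same scale. These three values all lie within the usual scatter of one another, so compound 3 stands in one group with the other two and none of them can be ranked.

Compound 4 `COc1ccccc1-c1cc(O)c2c(C)ccnc2n1` differs from compound 3 in a single place (methyl in place of hydrogen on an aromatic carbon): a methyl in place of hydrogen on an aromatic carbon, opposite the ring nitrogen. Comparing two compounds that differ in only one place is the simplest way to read such data. Within the data shown here, one measured step bears on this change, and it is the same exchange read backwards, on another aromatic carbon of the shared core (a 1.8-fold higher number from compound 2 to compound 3 (0.26 log units; within the scatter)). Among the measured compounds shown here, that step stays within the scatter, and no measured compound carries a methyl on the carbon that changes in compound 4. The expected step (a 1.3-fold lower number from compound 3 to compound 4 (0.12 log units; within the scatter)) is therefore none beyond the scatter, with only a slight lean to a lower number. For compound 4 the estimated value is 30000 nM with 12000 nM to 70000 nM as the expected range.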

Compound 4, concentration for 50% growth inhibition: 6460 nM
Estimate against measurement, compound 4: 4.6-fold (0.67 log units) above; measured number outside the range, below it.
By their numbers in this assay, from the lowest: compound 4; then compounds 1, 2 and 3 (each within the scatter of the next).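

In this assay, among these compounds, a methyl in place of hydrogen opposite the ring nitrogen gives a 6.2-fold lower number from compound 3 to compound 4 (0.79 log units; beyond the scatter), the only step in this small set that lies beyond the scatter. The same exchange on another aromatic carbon of the shared core, a 1.8-fold higher number from compound 2 to compound 3 (0.26 log units; within the scatter), stays within the scatter, so these two steps show that where the methyl sits can matter, not only that a methyl is present, although each place rests on a single pair of compounds. Nothing measured here gives a reason for the stronger inhibition of growth at this carbon.

The compounds shown carry only hydrogen or methyl on this carbon, so it remains open whether an ethyl group, a longer chain, a chlorine atom or an amine would push the number further down, leave it unchanged or reverse the step. As far as these compounds go, it is also open whether the methyl would give a similar step on compound 1, which gives 20000 nM without it, or how it would behave together with the methyl of compound 2.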